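Working notes: anilino in place of 4-methylpiperidinyl

A few compounds are considered here, and "the series" means these few. Any claim that something is new, unique, unknown or untested is made for them only; others in the source may bear on it.

All three measured compounds were read in a functional assay on HepG2 cells (Homo sapiens) for antiproliferative activity, read by CCK-8 assay, with a stated time of 72 h, tested at 8 uM; a higher number here means a stronger effect of the compound at the concentration tested, a lower number a weaker effect:
compound 1 `CC1CCN(c2nc(Cl)nc3c2ncn3Cc2ccc(/C=C/C(=O)Nc3ccccc3N)cc2)CC1` gives 32.2%
compound 2 `CCCCn1cnc2c(NCc3ccc(C(=O)Nc4ccccc4N)cc3)nc(Cl)nc21` gives 19.6%
compound 3 `CC1CCN(c2nc(Cl)nc3c2ncn3Cc2ccc(C(=O)Nc3ccccc3N)cc2)CC1` gives 65.3%

In this assay compound 1 stands second of the three, with compound 2 nearest and compound 3 furthest. Among the compounds with values here, the only single-site step in the set, a number 33.1 percentage points higher from compound 1 to compound 3 (beyond the scatter), concerns the linker to the amide and leaves the rest of the shared core untouched.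

Compound 4 `Nc1ccccc1NC(=O)/C=C/c1ccc(Cn2cnc3c(Nc4ccccc4)nc(Cl)nc32)cc1` keeps the linker and the amide of compound 1 and changes only the substituent on the core: anilino in place of 4-methylpiperidin-1-yl on an aromatic carbon. Within the data shown here, no measured step in the set touches this position, so the step 1>3 does not bear on it directly; it only shows that the set can move far on a single change. Compound 2 differs from compound 1 in more than one place, so its value is read beside compound 1 without drawing a step. Among the measured compounds shown here, with no direct precedent, the expectation for this assay is a step of no set direction, and the estimate is centred near compound 1 with a broad range.

For compound 4 the expected value in this assay is 32%, between 15% and 52%.

The estimated step of a number 0.2 percentage points lower from compound 1 to compound 4 (within the scatter) is thus expected to lie within the scatter.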

Compound 4, a percentage reported as inhibition, at one concentration (the size of the read-out at that concentration, not a potency): 41.9%
Compound 4: middle estimate off by 9.9 percentage points, on the low side, within the range that was stated.
By their numbers in this assay, from the lowest: compound 2; then compounds 1 and 4 (each within the scatter of the next); then compound 3.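

In this assay, within the data shown here, with the 2-((2-aminophenyl)carbamoyl)ethenyl group held constant, anilino in place of 4-methylpiperidin-1-yl gives a number 9.7 percentage points higher from compound 1 to compound 4 (within the scatter), the first direct reading of this position on the shared core; the only earlier single-site step, a number 33.1 percentage points higher from compound 1 to compound 3 (beyond the scatter), concerned the linker to the amide. The exchange replaces a six-membered non-aromatic ring with a six-membered aromatic ring of carbon only and adds a hydrogen-bond donor at an unchanged heavy-atom count, yet the step stays within the scatter, so this one change does not separate the two compounds in this read-out at the concentration tested. Nothing available bears on what lies behind this reading.

As far as these compounds go, it remains open whether anilino and 4-methylpiperidin-1-yl would also read alike on the shorter (2-aminophenyl)carbamoyl attachment of compound 3, where the value is more than the scatter away from that of compound 1. From the compounds shown here alone, it is also open how other groups at this position would read, such as N-methylanilino, which has no amine hydrogen, or morpholin-4-yl, which places an oxygen in the non-aromatic ring.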